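Mirror-Image Switch and the Expected Plasma Clearance

The source may hold more compounds than are shown below. What is called first, only, known or untested is meant among the compounds shown, and "the series" means these compounds.

Measured compounds:
compound 1, `CN(C)S(=O)(=O)N(C)[C@@H]1CCCn2c1nc(C(=O)NCc1ccc(F)cc1)c(O)c2=O`, 3.8 mL/min/kg
compound 2, `CN(C)C(=O)C(=O)N(C)[C@H]1CCCCn2c1nc(C(=O)NCc1ccc(F)cc1)c(O)c2=O`, 7.5 mL/min/kg

Both values come from an in vivo ADME assay on the whole organism (plasma) for pharmacokinetics, with Canis familiaris (Canis lupus familiaris) as the target; a higher number here means faster removal of the compound, a lower number slower removal. Compound 1 has the lower of the two numbers; its nearest neighbour is compound 2, and the gap between the two lies within the usual scatter of repeated measurements, so the pair gives no ranking. Among the compounds with values here, the two compounds differ in several places at once, and no single-change step between measured compounds is available.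

Compound 3, `CN(C)S(=O)(=O)N(C)[C@H]1CCCn2c1nc(C(=O)NCc1ccc(F)cc1)c(O)c2=O`, is the mirror image of compound 1 at its one stereocentre: the two compounds have the same atoms and bonds and differ only in configuration as drawn: 1 of 1 stereo elements differ; a stereocentre at a saturated ring carbon is drawn R in compound 1 and S in compound 3. Within the data shown here, nothing among the measured compounds shows how this assay responds to a change of configuration alone, so the expectation for compound 3 rests on compound 1 directly. The step from compound 1 to compound 3 is expected to be modest, with no clear direction and most likely not beyond the scatter: a 1.3-fold higher number from compound 1 to compound 3 (0.12 log units; within the scatter). In this assay compound 3 is therefore estimated at 5 mL/min/kg, within a range from 2.5 mL/min/kg to 12 mL/min/kg.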

Compound 3, clearance: 3.8 mL/min/kg
Estimate against measurement, compound 3: 1.3-fold (0.12 log units) above; the range from low to high includes it.
By their numbers in this assay, from the lowest: compounds 1, 3 and 2 (each within the scatter of the next).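

In this assay, the switch of the stereocentre at the saturated ring carbon, drawn R in compound 1 and S in compound 3, gives no change at the digits printed from compound 1 to compound 3 (within the scatter). This is the first direct reading of configuration alone among these compounds, since the earlier pair differed in several places at once and could say nothing about this stereocentre taken by itself. At this position, and for this pair, the read-out does not separate the two mirror-image forms, and no other structural difference enters the comparison: the fact that compounds 1 and 3 differ only in the configuration as drawn

The compounds shown leave open whether configuration at the corresponding carbon would count for as little in compound 2, which differs from compound 1 in several places at once, so that this one pair cannot be read as a rule for the whole series. They also leave open how this assay would respond to either form if the dimethylsulfamoyl group gave way to a different group at the same place, such as a carboxylic acid or a primary amine.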